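Swapping trifluoromethyl for chloro on two related antagonist series

This account rests on a few compounds, and the source may have more. Where it says the series, first, only, none or still open, it means among the compounds named here.

Compound 1 `O=C(CCCc1ccc2cccnc2n1)NCc1cc(-c2ccc(F)c(Cl)c2)no1` and compound 2 `O=C(CCCc1ccc2cccnc2n1)NCc1cc(-c2ccc(F)c(C(F)(F)F)c2)no1` share one core and differ only on the outer aromatic ring. In a functional assay on CHO-K1 cells for antagonist activity at succinate receptor 1 (Homo sapiens), read by FLIPR and calcium flux (on this read-out higher numbers stand for weaker inhibition and lower numbers for stronger inhibition), compound 2 gives 35 nM, while compound 1 gives 90 nM. For the measured compounds named here, the single change between them, (chloro in place of trifluoromethyl on an aromatic carbon), produced a 2.6-fold higher number from compound 2 to compound 1 (0.41 log units; beyond the scatter).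

Compound 3 `FC(F)(F)c1ccc(-c2nnc(CCCCc3ccc4cccnc4n3)o2)cc1C(F)(F)F` is built on a different core; how its core differs from that of compound 2 is not broken down here. In this assay compound 3 gives 170 nM.

Compound 4 `FC(F)(F)c1cc(-c2nnc(CCCCc3ccc4cccnc4n3)o2)ccc1Cl` is not yet measured. It is related to compound 3 by chloro in place of trifluoromethyl on an aromatic carbon. This is the same kind of change as that from compound 2 to compound 1, not the same change: in compound 2 the departing trifluoromethyl sits ortho to a fluoro group and meta to a large group, whereas in compound 3 it sits ortho to a trifluoromethyl group and para to a large group.

Going by the values given here, because the only measured example of this change gave a 2.6-fold higher number from compound 2 to compound 1 (0.41 log units; beyond the scatter), the step from compound 3 to compound 4 is expected to be a 2.1-fold higher number from compound 3 to compound 4 (0.31 log units; beyond the scatter), a weakening of similar size, softened somewhat since the surroundings of the change differ. In this assay compound 4 is therefore estimated to give 350 nM, expected to lie between 150 nM and 900 nM.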

Compound 4, half-maximal inhibitory concentration: 160 nM
Estimate against measurement, compound 4: 2.2-fold (0.34 log units) above; the range from low to high includes it.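

In this assay, putting chloro in place of trifluoromethyl on the core of compound 3 gave a 1.1-fold lower number from compound 3 to compound 4 (0.03 log units; within the scatter) and so left compound 3 and compound 4 within the scatter of each other. Set beside the same change on the core of compound 2, the two steps do not agree: the same change on two cores in this assay, a 2.6-fold higher number (0.41 log units; beyond the scatter) from compound 2 to compound 1 and a 1.1-fold lower number (0.03 log units; within the scatter) from compound 3 to compound 4, 2.7-fold (0.44 log units) apart, beyond the scatter of two such steps. This shows that the size of this swap did not carry from one core to the other in this series, so a step measured on one core is a poor guide to the same step on the other; it does not show why the two differ, as the pairs differ in their cores and also in the other groups on the outer ring, and one pair per core cannot pull these apart.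

Still open, as far as these compounds go, is whether the difference follows the core itself or those other groups on the ring, a question that a fluoro in place of the remaining trifluoromethyl of compound 4 would begin to test. Also open, from the compounds shown here alone, is whether the two cores would part in the same way for other groups on this carbon, such as bromo, methyl or a nitrile.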